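From 2-methoxyethoxy to ethyl on the shared core

The source may report more compounds than this note shows. Statements on the series, on what has been measured and on what is new or still open speak of the compounds shown alone.

In a physicochemical assay for lipophilicity, read by HPLC, at pH 7.4 (a lower number here means a more polar compound, a higher number a more lipophilic compound), compound 1 (`C[C@@H](Oc1cc2ccn(CCC(=O)O)c2cc1Cl)c1ccccn1`) gives 2.17 and compound 2 (`COCCOc1cc2oc(=O)n(CCC(=O)O)c2cc1Cl`) gives 0.88. Among the compounds with values here, compound 2 therefore holds the lower of the two numbers so far, and its distance from compound 1 lies beyond the scatter. Compound 3 (`CCc1cc2oc(=O)n(CCC(=O)O)c2cc1Cl`) still awaits measurement in this assay. It carries ethyl in place of 2-methoxyethoxy on an aromatic carbon, ortho to a chloro group: ethyl in place of 2-methoxyethoxy on an aromatic carbon. Within the data shown here, no measured pair shows this change, so the expectation rests on the structural change alone. A rise in this assay beyond the scatter is expected, and the estimated step is a number 0.82 log units higher from compound 2 to compound 3 (beyond the scatter). For compound 3 the estimated value is 1.7, with an expected range of 1.3 to 2.1.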

Compound 3, distribution coefficient: 1.94
Beside the measured number, compound 3's estimate is 0.24 log units below it; the measured number falls inside the stated range.
By their numbers in this assay, from the lowest: compound 2; then compounds 3 and 1 (each within the scatter of the next).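

In this assay, ethyl in place of 2-methoxyethoxy on an aromatic carbon, ortho to a chloro group, reads as a number 1.06 log units higher from compound 2 to compound 3 (beyond the scatter) and gives the series its first step that differs in one place. This single position on the shared core can therefore move the number by a large step beyond the scatter, with the rest of the structure unchanged.

One step cannot separate the loss of the two oxygen atoms in 2-methoxyethoxy from the shorter chain of ethyl. A butyl chain or a methoxy group at this position would pull those two differences apart, and an amine there would extend the comparison to a different kind of group. Nothing shown accounts for the size of this step.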